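Pentyl for Isopropyl in a Spirocyclic Glucagon Antagonist Series

The compounds below may be only part of what the source reports. "The series", "measured", "known", "first", "only" and "open" are said of these compounds alone.

Measured compounds:
compound 1 `C[C@H](c1ccc(C(=O)NCCC(=O)O)cc1)N1C(=O)C(c2cccc(Cl)c2)=N[C@]12CC[C@@H](C(C)(C)C)CC2` gives 480 nM
compound 2 `CC(C)(C)[C@H]1CC[C@]2(CC1)N=C(c1ccc(Cl)cc1)C(=O)N2Cc1ccc(C(=O)NCCC(=O)O)cc1` gives 1400 nM
compound 3 `CC(C)[C@H](c1ccc(C(=O)NCc2nn[nH]n2)cc1)N1C(=O)C(c2cc(Cl)cc(Cl)c2)=N[C@]12CC[C@@H](C(C)(C)C)CC2` gives 2200 nM

All three were tested in a functional assay on CHO cells for antagonist activity at Glucagon receptor (Homo sapiens), read by cAMP accumulation, with stated times of 30 min and 45 min; on this read-out higher numbers stand for weaker inhibition and lower numbers for stronger inhibition. Among them compound 3 carries the highest number. Its nearest neighbour is compound 2, whose value is lower by an amount that stays within the scatter of the measurement, so the two cannot be placed in order. Compound 1 lies further away, with a value lower than that of compound 3 by a gap that goes beyond the scatter, so compound 1 inhibits more strongly than compound 3 on this read-out.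

Compound 4 `CCCCC[C@H](c1ccc(C(=O)NCc2nn[nH]n2)cc1)N1C(=O)C(c2cc(Cl)cc(Cl)c2)=N[C@]12CC[C@@H](C(C)(C)C)CC2` has not been measured. It differs from compound 3 in one place: pentyl in place of isopropyl on a saturated chain carbon bound to an amide-type nitrogen in a ring and an aromatic carbon. Among the compounds with values here, no pair of measured compounds in this set differs in just this way, so there is no measured step to lean on for the size or direction of the change. With nothing in the data pointing either way, the step from compound 3 to compound 4 is expected to stay within the scatter, as a 1.1-fold lower number from compound 3 to compound 4 (0.04 log units; within the scatter) expresses. On that basis compound 4 is estimated at 2000 nM, with a range from 600 nM to 6500 nM.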

Compound 4, half-maximal inhibitory concentration: 130 nM
The estimate for compound 4 lay 15-fold (1.19 log units) above the measured number, and the stated range ends above it.
By their numbers in this assay, from the lowest: compound 4; then compound 1; then compounds 2 and 3 (each within the scatter of the next).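

In this assay, the saturated chain carbon bound to an amide-type nitrogen in a ring and an aromatic carbon proves sensitive to its substituent, as pentyl in place of isopropyl gives a 17-fold lower number from compound 3 to compound 4 (1.23 log units; beyond the scatter) and the step lies well beyond the scatter. Only carbon is added in this exchange, with no ring, hydrogen-bond donor, hydrogen-bond acceptor or net charge entering or leaving, and the change lengthens the chain while also removing its branch. No measurement shown here explains the size of this step.

From the compounds shown here alone, the two compounds cannot separate chain length from branching, so it remains open whether a straight propyl, a butyl or a hexyl at this carbon would give a number closer to that of compound 3 or to that of compound 4. Going by these compounds, it is also open whether pentyl would bring a similar step in compounds with the carboxylic acid side chain of compound 1, or whether an amine at the end of the pentyl chain would keep the effect.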